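The compounds below may be only part of what the source reports. "The series", "measured", "known", "first", "only" and "open" are said of these compounds alone.

In a functional assay for inhibition, with Homo sapiens as the target (on this read-out higher numbers stand for weaker binding and lower numbers for tighter binding), compound 3 `Cc1ccc(C#N)c(OC(C)(C)C2OCC(C/C=C\CCC(=O)O)C(c3cccnc3)O2)c1` gives 15.9 nM, the lowest number of the three and beyond the scatter from the others: compound 1 `O=C(O)CC/C=C\CC1COC(c2ccc(C(F)(F)F)cc2)OC1c1cccnc1` gives 1780 nM and compound 2 `O=C(O)CC/C=C\CC1COC(c2ccco2)OC1c1cccnc1` gives 1260 nM. Compound 4 `CC(C)(Oc1ccccc1F)C1OCC(C/C=C\CCC(=O)O)C(c2cccnc2)O1` differs from compound 3 in one place: 2-fluorophenyl in place of 2-cyano-5-methylphenyl on an oxygen on a saturated carbon. Within the data shown here, the only measured single change, a 1.4-fold lower number from compound 1 to compound 2 (0.15 log units; within the scatter), involves other groups in another place and stays within the scatter, so it says little about this swap. Among the measured compounds shown here, no measured step touches the group that leaves, and a moderate rise is tentatively expected, a 2.8-fold higher number from compound 3 to compound 4 (0.45 log units; beyond the scatter), well short of the gap separating compound 3 from compound 2. For compound 4 the estimated value is 45 nM, with an expected range from 12 nM to 200 nM.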

Compound 4, dissociation constant: 166 nM
Compound 4: middle estimate off by 3.7-fold (0.57 log units), on the low side; measured number inside the range.
By their numbers in this assay, from the lowest: compound 3; then compound 4; then compounds 2 and 1 (each within the scatter of the next).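

In this assay, among these compounds, the step of a 10-fold higher number from compound 3 to compound 4 (1.02 log units; beyond the scatter) shows that the group on this oxygen on a saturated carbon can move the number well beyond the scatter, unlike the only other measured single change, which stays within it. Because 2-cyano-5-methylphenyl and 2-fluorophenyl differ in nitrile, methyl and fluorine at once, the step cannot be assigned to any one of them. No available evidence accounts for its size.

Going by these compounds, whether 2-cyanophenyl would read nearer compound 3 or compound 4 remains open. So does the effect of a chlorine or a methoxy group in place of the fluorine.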